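The source may report more compounds than this note shows. Statements on the series, on what has been measured and on what is new or still open speak of the compounds shown alone.

Compound 1 `CC(C)[C@H](NC(=O)COc1cccc2ccccc12)C(=O)N[C@@H](CC(=O)O)C(=O)CSc1nccn1C`. In a functional assay on Jurkat cells (Homo sapiens) for inhibition (on this read-out higher numbers stand for weaker inhibition and lower numbers for stronger inhibition), compound 1 gives > 200000 nM, which is a limit of the assay and not a number.
Compound 2 `CC(C)[C@H](NC(=O)COc1cccc2ccccc12)C(=O)N[C@@H](CC(=O)O)C(=O)COc1nc2ccccc2[nH]1`. In this assay compound 2 gives > 200000 nM, again a limit rather than a number.
Compound 3 `CC(C)[C@H](NC(=O)COc1cccc2ccccc12)C(=O)N[C@@H](CC(=O)O)C(=O)COc1cncc2ccccc12`. In this assay compound 3 gives 166000 nM.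

Among the compounds with values here, compound 3 therefore carries the only real number in this set; the other two compounds sit at the ceiling of the assay, (the limit of > 200000 nM in this assay, at which 2 of the 3 values shown sit). All three share the same core and differ only in the group attached through the chain beside the carbonyl.

Compound 4 `CC(C)[C@H](NC(=O)COc1cccc2ccccc12)C(=O)N[C@@H](CC(=O)O)C(=O)COc1nccc2ccccc12` keeps that pattern, and its difference from compound 3 is isoquinolin-1-yl in place of isoquinolin-4-yl on an oxygen on a saturated carbon. The steps measured so far concern this same position: an at least 1.2-fold lower number from compound 2 to compound 3 (0.08 log units; that floor lies within the scatter) and an at least 1.2-fold lower number from compound 1 to compound 3 (0.08 log units; that floor lies within the scatter). Both are floors set by a limit, and both swap one ring system for another, whereas the present change only moves the nitrogen within the same two rings. The measured steps thus give no direct guide to its direction, and the expected step is a 1.0-fold lower number from compound 3 to compound 4 (0.02 log units; within the scatter), a change not beyond the scatter. Compound 4 is accordingly estimated at 160000 nM, within a range from 50000 nM to 400000 nM.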

Compound 4, half-maximal inhibitory concentration: 106000 nM
Compound 4: middle estimate off by 1.5-fold (0.18 log units), on the high side, and the stated range covers the measured number.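

Within the data shown here, this is the first comparison in the set with a real number at both ends: isoquinolin-1-yl in place of isoquinolin-4-yl gives a 1.6-fold lower number from compound 3 to compound 4 (0.19 log units; within the scatter), so in this assay moving the ring nitrogen within the same two rings does not separate the two compounds. The comparisons with the other groups read an at least 1.8-fold lower number from compound 2 to compound 4 (0.27 log units; that floor lies within the scatter) and an at least 1.8-fold lower number from compound 1 to compound 4 (0.27 log units; that floor lies within the scatter); both are floors that lie within the scatter, so they set no order among these groups. They remain floors since compound 1 and compound 2 carry limits and not numbers: the limit of > 200000 nM in this assay, at which 2 of the 4 values shown sit.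

On these data alone, what stays open is whether any group at this position can move the number beyond the scatter. An amine on the isoquinolin-1-yl group, or a longer chain carrying that group, would test this.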